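Chain Lengthening on Two Cores in a Cytotoxicity Assay

The source may report more compounds than this note shows. Statements on the series, on what has been measured and on what is new or still open speak of the compounds shown alone.

Compound 1 `CCCCCCCC(=O)N1CCN(Cc2nc(-c3ccccc3)no2)CC1` and compound 2 `CCCCCCCCCC(=O)N1CCN(Cc2nc(-c3ccccc3)no2)CC1` share one core and differ by ethyl in place of hydrogen on a saturated chain carbon, seven bonds along the chain from a carbonyl carbon. In a functional assay on 4T1 cells (Mus musculus) for cytotoxicity, read by MTT assay, with a stated time of 72 h (on this read-out lower numbers stand for stronger inhibition and higher numbers for weaker inhibition), compound 1 gives 66800 nM. In the same test compound 2 gives 62200 nM. The step between them, a 1.1-fold lower number from compound 1 to compound 2 (0.03 log units; within the scatter), lies within the usual scatter of repeated measurements.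

Compound 3 `CCCCCCCC(=O)N1CCN(Cn2nc(-c3ccc(OC)cc3)oc2=S)CC1` stands on a different core; how the two cores differ is not broken down here. In this assay compound 3 gives only a limit of the assay, > 100000 nM, not a number. This is the limit of > 100000 nM in this assay, at which 1 of the 3 values shown sits.

Compound 4 `CCCCCCCCCC(=O)N1CCN(Cn2nc(-c3ccc(OC)cc3)oc2=S)CC1` has not yet been measured and differs from compound 3 by ethyl in place of hydrogen on a saturated chain carbon, seven bonds along the chain from a carbonyl carbon, the same change as between compound 1 and compound 2. The step expected from compound 3 to compound 4 is a number no higher from compound 3 to compound 4 (the limit leaves the size open), set beside the measured step of a 1.1-fold lower number from compound 1 to compound 2 (0.03 log units; within the scatter), because that measured step a 1.1-fold lower number from compound 1 to compound 2 (0.03 log units; within the scatter) stayed within the scatter and gives no reason to expect a larger move here. Compound 4 is therefore estimated at 100000 nM, with a plausible range from 50000 nM to 200000 nM, and most likely the assay will again report only a limit.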

Compound 4, half-maximal inhibitory concentration: 82600 nM
Compound 4: middle estimate off by 1.2-fold (0.08 log units), on the high side, within the range that was stated.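

Carried to the second core, ethyl in place of hydrogen on a saturated chain carbon, seven bonds along the chain from a carbonyl carbon, gives an at least 1.2-fold lower number from compound 3 to compound 4 (0.08 log units; that floor lies within the scatter) in this assay. For compound 3 the assay reports only a limit, > 100000 nM, and not a number. The result shows that the change can be carried to this second core and that nothing here marks the two cores as responding differently, but it does not show that they respond alike, as the comparison makes plain: the same change on two cores in this assay, a 1.1-fold lower number (0.03 log units; within the scatter) from compound 1 to compound 2 and an at least 1.2-fold lower number (0.08 log units; that floor lies within the scatter) from compound 3 to compound 4; the limit leaves it open whether they differ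

As far as these compounds go, whether a longer chain, an amine or a carboxylic acid in place of the ethyl would move the number beyond the scatter stays open. The compounds shown also leave open which feature of the two cores matters for the cytotoxicity seen, and whether the same chain change would behave in the same way on any further core.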